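The source may hold more compounds than are shown below. What is called first, only, known or untested is meant among the compounds shown, and "the series" means these compounds.

In a functional assay on OVCAR-3 cells (Homo sapiens) for inhibition, read by sulforhodamine B assay, with a stated time of 48 h (on this read-out lower numbers stand for stronger inhibition and higher numbers for weaker inhibition), compound 2 (`COc1cc(-c2nn(-c3cccc(NC(=O)Nc4ccc(Cl)c(Cl)c4)c3)cc2-c2ccncc2)ccc1Cl`) gives 700 nM. Compound 1 (`O=C(Nc1cccc(-n2cc(-c3ccncc3)c(-c3ccc(Cl)c(O)c3)n2)c1)Nc1cccc(C(F)(F)F)c1`) gives 1060 nM in this assay, and the two numbers lie within the usual scatter of each other. Compound 3 (`O=C(Nc1cccc(-n2cc(-c3ccncc3)c(-c3ccc(Cl)c(O)c3)n2)c1)Nc1ccc(Cl)c(Cl)c1`) differs from compound 2 by a single change, (hydrogen in place of methyl on an oxygen on an aromatic ring). For the measured compounds named here, no measured pair shows this change on its own, so no step is known for it. The step is expected to be a 1.1-fold higher number from compound 2 to compound 3 (0.03 log units; within the scatter), not beyond the scatter in either direction. The estimate for compound 3 is 750 nM, with a range from 300 nM to 1900 nM.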

Compound 3, half-maximal inhibitory concentration: 1050 nM
Beside the measured number, compound 3's estimate is 1.4-fold (0.15 log units) below it; the measured number falls inside the stated range.
By their numbers in this assay, from the lowest: compounds 2, 3 and 1 (each within the scatter of the next).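

In this assay, hydroxy in place of methoxy on the aromatic ring gives a 1.5-fold higher number from compound 2 to compound 3 (0.18 log units; within the scatter) and so leaves the two groups indistinguishable at this position. 3,4-Dichlorophenyl in place of 3-(trifluoromethyl)phenyl on the amide-type nitrogen gives a 1.0-fold lower number from compound 1 to compound 3 (0.00 log units; within the scatter) and shows the same for that second place. Nothing available explains either result. The compounds shown leave open whether an amine, a carboxylic acid or a longer chain such as ethoxy in place of the hydroxy would shift the number beyond the scatter.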